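The source may hold more compounds than are shown below. What is called first, only, known or untested is meant among the compounds shown, and "the series" means these compounds.

The measured compounds:
Compound 1 `CN(CCC(Oc1ccc(C(F)(F)F)cc1)c1ccc(F)cc1)CC(=O)O` gives 251 nM in an assay on CHO cells for inhibition of sodium- and chloride-dependent glycine transporter 1 (Homo sapiens); on this read-out higher numbers stand for weaker inhibition and lower numbers for stronger inhibition.
Compound 2 `CN(CCC(Oc1cccc(C(F)(F)F)c1)c1ccccc1)CC(=O)O` gives 2510 nM in this assay.
Compound 3 `COc1ccc(C(CCN(C)CC(=O)O)Oc2ccc(C(F)(F)F)cc2)cc1` gives 501 nM in this assay.

Compound 3 stands second highest of the three. Compound 1 lies within the scatter of it, while compound 2 lies beyond the scatter, with a higher number. Compound 4 `CN(CCC(Oc1ccc(C(F)(F)F)cc1)c1ccc(Cl)cc1)CC(=O)O` differs from compound 3 by chloro in place of methoxy on an aromatic carbon. Within the data shown here, only one measured step touches this position: a 2.0-fold higher number from compound 1 to compound 3 (0.30 log units; within the scatter), which shows that exchanging the group there moved the number little. The expectation is therefore a step of a 1.6-fold lower number from compound 3 to compound 4 (0.19 log units; within the scatter), not beyond the scatter. Compound 4 is expected at 320 nM, with a range from 120 nM to 900 nM.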

Compound 4, half-maximal inhibitory concentration: 100 nM
Compound 4: middle estimate off by 3.2-fold (0.51 log units), on the high side, outside the stated range (below it).
By their numbers in this assay, from the lowest: compound 4; then compounds 1 and 3 (each within the scatter of the next); then compound 2.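

Chloro in place of methoxy gives a 5.0-fold lower number from compound 3 to compound 4 (0.70 log units; beyond the scatter) and chloro in place of fluoro gives a 2.5-fold lower number from compound 1 to compound 4 (0.40 log units; beyond the scatter) while the only earlier step at this position stayed within the scatter. The group on this aromatic carbon therefore does change the number, and among the three groups seen there chloro gives the lowest. From the compounds shown here alone, whether a bromo or a methyl group on the same carbon would give a lower number still remains open. No measurement shown here accounts for the difference between these groups.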